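The compounds below may be only part of what the source reports. "The series", "measured", "known", "first", "only" and "open" are said of these compounds alone.

Compound 1 `CC(=O)N1CCC(c2nc(NCc3ccccn3)ncc2-c2cc(C)no2)CC1` gives 221000 nM in a physicochemical assay for solubility, with a stated time of 24 h, at pH 3; on this read-out lower numbers stand for lower solubility and higher numbers for higher solubility. Compound 2 `CC(=O)N1CCC(c2nc(N3CCN(C)CC3)ncc2-c2cc(C)no2)CC1` gives 225000 nM. Compound 3 `COCCNc1ncc(-c2cc(C)no2)c(C2CCN(C(C)=O)CC2)n1` gives 233000 nM.

These three compounds share one core and differ only in the group attached to it at a single position: compound 3 carries a (2-methoxyethyl)amino group, compound 2 a 4-methylpiperazin-1-yl group and compound 1 a ((pyridin-2-yl)methyl)amino group. In this assay compound 3 cannot be set apart from the other two, since the steps of a 1.1-fold higher number from compound 1 to compound 3 (0.02 log units; within the scatter) and a 1.0-fold higher number from compound 2 to compound 3 (0.02 log units; within the scatter) are both within the scatter, as is a 1.0-fold higher number from compound 1 to compound 2 (0.01 log units; within the scatter).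

Compound 4 `CC(=O)N1CCC(c2nc(NC(C)C)ncc2-c2cc(C)no2)CC1` has not yet been measured. Its change from compound 3 is isopropyl in place of 2-methoxyethyl on a nitrogen on an aromatic ring. Among the compounds with values here, no measured step swaps exactly these two groups, but every measured step alters this same site, replacing one kind of group by another, and none of them moved the number beyond the scatter. The bearing of those steps on the present change is therefore simple: three different groups at this position gave numbers that are indistinguishable, and a fourth group is expected to do the same. Compound 4 is therefore expected to show a 1.2-fold lower number from compound 3 to compound 4 (0.07 log units; within the scatter), nothing beyond the scatter. The estimate for compound 4 in this assay is 200000 nM, with a range from 100000 nM to 260000 nM.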

Compound 4, solubility: 224000 nM
The estimate for compound 4 lay 1.1-fold (0.05 log units) below the measured number; measured number inside the range.
By their numbers in this assay, from the lowest: compounds 1, 4, 2 and 3 (each within the scatter of the next).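

In this assay, isopropyl in place of 2-methoxyethyl on this nitrogen (a 1.0-fold lower number from compound 3 to compound 4 (0.02 log units; within the scatter)) removes the oxygen of the chain and its one hydrogen-bond acceptor, and the number stays within the scatter. Each earlier group at this site held an oxygen or a further nitrogen, whereas isopropyl is made of carbon alone, yet compound 4 also cannot be set apart from the two compounds whose groups contain a ring (a 1.0-fold lower number from compound 2 to compound 4 (0.00 log units; within the scatter) and a 1.0-fold higher number from compound 1 to compound 4 (0.01 log units; within the scatter)). The indistinguishable readings therefore now extend to an all-carbon group with no ring, so at this pH the four compounds show no dependence of the number on which of these groups sits here.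

Still open, on these data alone, is whether a carboxylic acid or a much longer hydrocarbon chain at this site would stay within the scatter too, and what a change elsewhere on the shared core, such as replacing the acetyl group, would do. Nothing in the available data explains why these four groups give such closely matching numbers.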